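Swapping a Side Group on a Stable Compound

The source may report more compounds than this note shows. Statements on the series, on what has been measured and on what is new or still open speak of the compounds shown alone.

compound 1 `CC(=O)N[C@@H](C)/C=C/c1ccc(Oc2ccc3nc(C)sc3c2Cl)nc1` 75%
compound 2 `CC(=O)N[C@@H](C)/C=C/c1ccc(Oc2ccc3nc(C(C)(C)O)sc3c2Cl)nc1` 96%

In an ADME assay on microsomes from liver (Rattus norvegicus) for metabolic stability, with a stated time of 30 min (a higher number here means that more of the compound is left, a lower number that less of the compound is left), compound 2 stands highest of the two, at 96%. Compound 3 `CCOc1nc2ccc(Oc3ccc(/C=C/[C@H](C)NC(C)=O)cn3)c(Cl)c2s1` differs from it in one group, ethoxy in place of 1-hydroxy-1-methylethyl (ethoxy in place of 1-hydroxy-1-methylethyl on an aromatic carbon). Going by the values given here, only one measured step bears on this carbon, a number 21 percentage points higher from compound 1 to compound 2 (beyond the scatter), which brought in that same group in place of methyl. Among the compounds with values here, no measured compound carries ethoxy, so the guess is loose: removing the group may undo a similar, modest amount. The expected change is a number 24 percentage points lower from compound 2 to compound 3 (beyond the scatter). For compound 3 the estimated value is 72%, with an expected range from 45% to 92%.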

Compound 3, percent of the compound remaining: 100%
Compound 3: middle estimate off by 28 percentage points, on the low side; measured number outside the range, above it.
By their numbers in this assay, from the lowest: compound 1; then compounds 2 and 3 (each within the scatter of the next).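

In this assay, going by these compounds alone, 1-hydroxy-1-methylethyl proves not to be the only group at this position that leaves more of the compound than methyl: swapping it for ethoxy, which has no hydrogen-bond donor, changes little (a number 4 percentage points higher from compound 2 to compound 3 (within the scatter)). Ethoxy also stands clear of methyl (a number 25 percentage points higher from compound 1 to compound 3 (beyond the scatter)). Nothing measured here explains this result.

As far as these compounds go, what remains open is whether an amine, a carboxylic acid or a longer ether chain on this carbon would give the same result. The compounds shown also leave open whether ethoxy would hold up in liver microsomes from other species.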